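Aryl Swap at the Ring Nitrogen of a Shared Core

A few compounds are considered here, and "the series" means these few. Any claim that something is new, unique, unknown or untested is made for them only; others in the source may bear on it.

The measured compounds:
compound 1, `CCCCCCNc1nc(SCc2ccc(C(F)(F)F)cc2)nc2ccccc12`, 19000 nM in a functional assay on PC-3 cells (Homo sapiens) for cytotoxicity, read by MTT assay, with a stated time of 72 h; a higher number here means a weaker inhibitor, a lower number a stronger inhibitor;
compound 2, `CCOc1ccccc1Nc1nc(SCc2ccc(C(F)(F)F)cc2)nc2ccccc12`, 26200 nM in this assay.

Within the data shown here, compound 2 holds the highest of the two numbers so far, but its only neighbour is compound 1, and the step of a 1.4-fold higher number from compound 1 to compound 2 (0.14 log units; within the scatter) is within the scatter, so the two stand level. Compound 3, `O=[N+]([O-])c1cccc(Nc2nc(SCc3ccc(C(F)(F)F)cc3)nc3ccccc23)c1`, has not yet been measured. The change from compound 2 reads (3-nitrophenyl in place of 2-ethoxyphenyl on a nitrogen on an aromatic ring). Among the measured compounds shown here, only one measured step touches this position, a 1.4-fold higher number from compound 1 to compound 2 (0.14 log units; within the scatter), and it shows that replacing hexyl by 2-ethoxyphenyl left the number where it was. For the measured compounds named here, no measured step tests 3-nitrophenyl, so the expectation for compound 3 rests on that single indifferent step and carries wide uncertainty. Compound 3 is therefore expected to land close to compound 2, a step of a 1.0-fold lower number from compound 2 to compound 3 (0.02 log units; within the scatter), with an estimate of 25000 nM and a range from 9000 nM to 70000 nM.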

Compound 3, half-maximal inhibitory concentration: 13500 nM
The estimate for compound 3 lay 1.9-fold (0.27 log units) above the measured number, and the stated range covers the measured number.
By their numbers in this assay, from the lowest: compounds 3, 1 and 2 (each within the scatter of the next).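

In this assay the step of a 1.9-fold lower number from compound 2 to compound 3 (0.29 log units; within the scatter) and the step of a 1.4-fold lower number from compound 1 to compound 3 (0.15 log units; within the scatter) show that 3-nitrophenyl on this nitrogen stands level with both 2-ethoxyphenyl and hexyl. Among these compounds, the single earlier step had compared only one aryl group with a chain, whereas two differently substituted aryl groups and the hexyl chain now cannot be told apart among the three compounds. No supporting measurement is available that would account for this flat picture.

Going by these compounds, whether an amine, a carboxylic acid or a chain longer than hexyl on this nitrogen would give a step beyond the scatter remains open. On these data alone, it is also open whether the same indifference would hold with a different group elsewhere on the shared core.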